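A few compounds are considered here, and "the series" means these few. Any claim that something is new, unique, unknown or untested is made for them only; others in the source may bear on it.

Working notes on a series sharing one core, read in an ADME assay on MDBK cells (Bos taurus) for cytotoxicity; on this read-out lower numbers stand for higher toxicity in this test and higher numbers for lower toxicity in this test. Compound 1 (`COc1cccc(Cn2ccc3nc(-c4ccccc4)nc-3c2)c1`) gives > 100000 nM, a limit of the assay and not a number. Compound 2 (`Fc1ccccc1Cn1ccc2nc(-c3ccccc3)nc-2c1`) gives > 100000 nM, again a limit. Compound 3 (`c1ccc(CCCn2ccc3nc(-c4ccccc4)nc-3c2)cc1`) gives > 100000 nM, also a limit. Compound 3 therefore stands with the others, and the whole record so far is the limit of > 100000 nM in this assay, at which 3 of the 3 values shown sit.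

Compound 4 (`C(=C/c1ccccc1)\Cn1ccc2nc(-c3ccccc3)nc-2c1`) is not yet measured. It carries 2-phenylethenyl in place of phenethyl on a saturated chain carbon bound to an aromatic nitrogen.

The measured steps that bear on this change are those at the same place: a step that the two limits leave unreadable from compound 1 to compound 3, a step that the two limits leave unreadable from compound 2 to compound 3 and a step that the two limits leave unreadable from compound 1 to compound 2. None of them has a readable size, so no measured size can be carried over. All they show is that each of these groups ends at the limit. On that basis, no step beyond the scatter is expected in this assay, and a further limit is the likeliest report. The expected change is a number no higher from compound 3 to compound 4 (the limit leaves the size open). For compound 4 the estimate is 100000 nM, with an expected range from 50000 nM to 200000 nM.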

Compound 4, half-maximal cytotoxic concentration: 78000 nM
Beside the measured number, compound 4's estimate is 1.3-fold (0.11 log units) above it; low and high end bracket the measured number.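

Compound 4 is the only compound shown that gives a number rather than a limit in this assay, so a substituent on a saturated chain carbon bound to an aromatic nitrogen can bring the read-out inside the measurable range: the limit of > 100000 nM in this assay, at which 3 of the 4 values shown sit.

Setting 2-phenylethenyl, with its 1 double bond outside aromatic rings, in place of phenethyl gives an at least 1.2-fold lower number from compound 3 to compound 4 (0.10 log units; that floor lies within the scatter), and the other two comparisons at this place give an at least 1.2-fold lower number from compound 2 to compound 4 (0.10 log units; that floor lies within the scatter) and an at least 1.2-fold lower number from compound 1 to compound 4 (0.10 log units; that floor lies within the scatter). Each of these is only a floor lying within the scatter, so no difference in toxicity in this test is established between compound 4 and the other compounds, and the steps among compound 1, compound 2 and compound 3 still cannot be read.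

The true size of all these steps stays open, as does whether the double bond is what matters, given that compound 3 and compound 4 are the only saturated and unsaturated pair shown. Also open, going by these compounds, is what an amine, a carboxylic acid or a longer chain at this place would give in this assay.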